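The compounds below may be only part of what the source reports. "The series", "measured", "known", "first", "only" and "open" are said of these compounds alone.

In an ADME assay on microsomes from liver (Mus musculus) for metabolic stability, read by LC-MS, using NADPH, tested at 4.6 uM (a lower number here means that the compound disappears faster, a higher number that the compound lasts longer), compound 2 (`O=C(NCCCCc1ccccc1)n1cc(-c2ccc(F)cc2)oc1=O`) gives 1 h as a measured number. Compound 3 (`CN1CCC(c2cc(F)ccc2-c2cn(C(=O)NCCCCc3ccccc3)c(=O)o2)CC1`) gives only a limit (> 1 h). That leaves a number no lower from compound 2 to compound 3 (the limit leaves the size open) open in size. Compound 4 (`CCCCCNC(=O)n1cc(-c2ccc(F)cc2C2CCN(C)CC2)oc1=O`) changes the chain of compound 3 (methyl in place of phenyl on a saturated chain carbon, four bonds along the chain from an amide-type nitrogen), with methyl in place of phenyl on a saturated chain carbon, four bonds along the chain from an amide-type nitrogen. Among the compounds with values here, no measured step covers this change. Compound 1 (`CCCCCNC(=O)n1cc(-c2ccccc2)oc1=O`) carries the chain of compound 4, and compound 1 gives only a limit (< 0.0834 h). That limit points to a shorter half-life for compound 4, although compound 1 also differs elsewhere. A fall beyond the scatter in this assay is expected, shown as an at least 5.0-fold lower number from compound 3 to compound 4 (0.69 log units; beyond the scatter) here. Compound 4 is estimated at 0.2 h with an expected range of 0.07 h to 0.7 h in this read-out.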

Compound 4, half-life: > 1 h
Compound 4 was reported as a limit; the forecaster's own chance of this, stated with the estimate: 35%; middle value at least 5.0-fold (0.69 log units) from the limit.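

In this assay, within the data shown here, compound 3 and compound 4 both stand only as limits, and no step between them can be read. The compounds shown leave open how far either half-life lies past its limit, and whether methyl in place of phenyl on the chain changes it.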